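The source may report more compounds than this note shows. Statements on the series, on what has been measured and on what is new or still open speak of the compounds shown alone.

Measured compounds in a toxicity assay on L02 cells (Homo sapiens) for cytotoxicity, read by MTT assay, with a stated time of 72 h; a higher number here means a weaker inhibitor, a lower number a stronger inhibitor:
- compound 1 `O=C1c2c[n+]([O-])c3ccccc3c2C(=O)c2c1c1ccccc1n2Cc1cn([C@H]2C[C@H](O)[C@@H](CO)O2)nn1` gives 280 nM
- compound 2 `O=C1c2c[n+]([O-])c3ccccc3c2C(=O)c2c1c1ccccc1n2Cc1cn([C@@H]2C[C@H](O)[C@@H](CO)O2)nn1` gives 630 nM
- compound 3 `CC1(C)OC[C@H](Cn2cc(Cn3c4c(c5ccccc53)C(=O)c3c[n+]([O-])c5ccccc5c3C4=O)nn2)O1` gives 470 nM

Compound 1 stands at the lowest number of the three in this assay. Its step to compound 3 is a 1.7-fold higher number from compound 1 to compound 3 (0.22 log units; within the scatter), so these two cannot be told apart; only compound 2 stands apart, with a 2.3-fold higher number from compound 1 to compound 2 (0.35 log units; beyond the scatter), a shift arising from the fact that compounds 1 and 2 differ only in the configuration as drawn.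

Compound 4 `O=C1c2c[n+]([O-])c3ccccc3c2C(=O)c2c1c1ccccc1n2Cc1cn(C[C@H](O)CO)nn1` is not yet measured. Relative to compound 1 it carries 2,3-dihydroxypropyl in place of 4-hydroxy-5-(hydroxymethyl)oxolan-2-yl on an aromatic nitrogen.

Among the compounds with values here, the steps that bear on this are those in which the same oxolane group is exchanged for an open-chain substituent: a 1.7-fold higher number from compound 1 to compound 3 (0.22 log units; within the scatter) and a 1.3-fold lower number from compound 2 to compound 3 (0.13 log units; within the scatter). Both stay within the scatter, so the sugar ring itself does not appear to set the number in this assay. On that basis the expected step for compound 4 is a 1.4-fold higher number from compound 1 to compound 4 (0.15 log units; within the scatter), that is, no change beyond the scatter, leaning if anything toward a slightly higher number as seen for compound 3.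

For compound 4 in this assay the estimate is 400 nM, with a range from 180 nM to 900 nM.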

Compound 4, half-maximal inhibitory concentration: 1130 nM
Compound 4: the middle estimate sits 2.8-fold (0.45 log units) below what was measured; the measured number lies above the stated range.
By their numbers in this assay, from the lowest: compounds 1, 3, 2 and 4 (each within the scatter of the next, the first and the last beyond it).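

In this assay the exchange of 4-hydroxy-5-(hydroxymethyl)oxolan-2-yl for 2,3-dihydroxypropyl on the aromatic nitrogen gives a 4.0-fold higher number from compound 1 to compound 4 (0.61 log units; beyond the scatter) and so shows that this position can respond to an open-chain group, which compound 3 had not shown. Compound 3 is also separated from the free diol chain, as 1,2-dihydroxyethyl in place of 2,2-dimethyl-1,3-dioxolan-4-yl gives a 2.4-fold higher number from compound 3 to compound 4 (0.38 log units; beyond the scatter) and the two open-chain groups therefore do not read alike, while the same exchange starting from the other drawn configuration of the oxolane gives a 1.8-fold higher number from compound 2 to compound 4 (0.25 log units; within the scatter) and shows no separation. Nothing available accounts for these steps.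

Going by these compounds, what an amine, a carboxylic acid or a longer chain would give in place of 2,3-dihydroxypropyl remains open. So does the effect of the opposite configuration at the one defined stereocentre of that chain.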